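Trifluoromethyl in place of methoxycarbonyl in a flat series

The compounds below may be only part of what the source reports. "The series", "measured", "known", "first", "only" and "open" are said of these compounds alone.

Compound 1 `CCc1ccc(NC(=O)Nc2cc(C)nc3ccccc23)cc1`: 17000 nM
Compound 2 `CC(=O)c1ccc(NC(=O)Nc2cc(C)nc3ccccc23)cc1`: 19000 nM
Compound 3 `COC(=O)c1ccc(NC(=O)Nc2cc(C)nc3ccccc23)cc1`: 20000 nM

All three values come from an ADME assay on HepG2 cells (Homo sapiens) for cytotoxicity, with a stated time of 72 h; on this read-out higher numbers stand for an effect only at larger amounts of compound and lower numbers for an effect already at smaller amounts. Compound 3, at 20000 nM, does not stand apart from the other two, since its gaps to both lie within the scatter. The next compound to be tested is compound 4 `Cc1cc(NC(=O)Nc2ccc(C(F)(F)F)cc2)c2ccccc2n1`, which differs from compound 3 at a single place: trifluoromethyl in place of methoxycarbonyl on an aromatic carbon. In words, this is trifluoromethyl in place of methoxycarbonyl on an aromatic carbon.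

The measured steps that bear on this change are those made at the same place. They are a 1.1-fold higher number from compound 1 to compound 2 (0.05 log units; within the scatter), a 1.2-fold higher number from compound 1 to compound 3 (0.07 log units; within the scatter) and a 1.1-fold higher number from compound 2 to compound 3 (0.02 log units; within the scatter). All of them lie within the scatter, so the ethyl, acetyl and methoxycarbonyl compounds cannot be told apart on these numbers. Among the measured compounds shown here, none of the measured compounds carries trifluoromethyl, however, and three compounds make only a narrow basis. On these data alone, on that basis, no step beyond the scatter is expected in this assay, and the direction stays open. The expected step is a 1.2-fold lower number from compound 3 to compound 4 (0.07 log units; within the scatter). For compound 4 the estimated value is 17000 nM, with an expected range from 9000 nM to 32000 nM.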

Compound 4, half-maximal effective concentration: 23000 nM
For compound 4 the middle estimate is 1.4-fold (0.13 log units) below the measured one; the measured number falls inside the stated range.
By their numbers in this assay, from the lowest: compounds 1, 2, 3 and 4 (each within the scatter of the next).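

In this assay, trifluoromethyl on this aromatic carbon, para to a large group, gives a number that cannot be told apart from those of the three earlier groups: methoxycarbonyl (a 1.2-fold higher number from compound 3 to compound 4 (0.06 log units; within the scatter)), acetyl (a 1.2-fold higher number from compound 2 to compound 4 (0.08 log units; within the scatter)) and ethyl (a 1.4-fold higher number from compound 1 to compound 4 (0.13 log units; within the scatter)). The earlier compounds had shown no fluorine-bearing group at this place, and this change also replaces a group with hydrogen-bond acceptors by one with none, yet the step stays within the scatter, so the flat picture now extends to four groups. Nothing available explains this flatness or links it to any property of these groups.

Among the compounds shown here, it remains open whether an amine, a carboxylic acid or a longer chain at this place would also stay within the scatter of these four compounds, or would be the first group here to stand apart from them. The compounds shown also leave open whether trifluoromethyl in place of methoxycarbonyl would behave the same way on a different core, or whether any change elsewhere on the shared core would move the number beyond the scatter.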